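The source may hold more compounds than are shown below. What is called first, only, known or untested is meant among the compounds shown, and "the series" means these compounds.

All three measured compounds were tested in a functional assay on Umbilical vein for antagonist activity at B1 bradykinin receptor (Homo sapiens), using Schild analysis, with a stated time of 30 min; a lower number here means a less potent compound, a higher number a more potent compound, by a factor of ten per unit of this negative logarithm.

Compound 1 `COc1cc(C)c(S(=O)(=O)N(C)CCOCC(=O)N2CCC(C3CCN(C)CC3)CC2)c(C)c1` gives 9
Compound 2 `COc1cc(C)c(S(=O)(=O)N(C)CCOCC(=O)N2CCN(CC3CCN(C)CC3)CC2)c(C)c1` gives 8.6
Compound 3 `Cc1c(Cl)cccc1S(=O)(=O)N(C)CCOCC(=O)N(C)Cc1ccc(C2=NCCN2)cc1` gives 8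

Compound 1 stands highest of the three in this assay. The nearest is compound 2, whose value in this assay, 8.6, lies lower by more than the usual scatter, and the furthest is compound 3, whose value, 8, lies lower still. Both steps are therefore real differences, not noise, and compound 1 can be called the most potent of the three.

Compound 4 `COc1cc(C)c(S(=O)(=O)N(C)CCOCC(=O)N2CCC(CN3CCN(C)CC3)CC2)c(C)c1` is an untested variant of compound 1. The change is (4-methylpiperazin-1-yl)methyl in place of 1-methylpiperidin-4-yl on a saturated ring carbon. Compound 2 shows what happens in a related case: it also carries a longer, two-ring tail on the shared core and sits modestly below compound 1. Within the data shown here, no directly comparable pair exists for the change to compound 4, so the expectation rests on that analogy. The step from compound 1 to compound 4 in this assay is expected to be a small loss, a number 0.40 log units lower from compound 1 to compound 4 (beyond the scatter), about the size seen for compound 2. Compound 4 is thus estimated at 8.6 in this assay, with a likely range from 8 to 9.2.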

Compound 4, negative logarithm of the antagonist equilibrium constant: 8.1
Compound 4: middle estimate off by 0.50 log units, on the high side; the measured number falls inside the stated range.
By their numbers in this assay, from the lowest: compounds 3 and 4 (each within the scatter of the next); then compound 2; then compound 1.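

At this saturated ring carbon, three ring bonds from the ring nitrogen, replacing 1-methylpiperidin-4-yl with (4-methylpiperazin-1-yl)methyl gives, in this assay, a number 0.90 log units lower from compound 1 to compound 4 (beyond the scatter), so this position does not tolerate every two-ring tail equally well. The change alters two things at once: the ring gains a second hetero atom, and the group grows from 7 to 8 heavy atoms, with a methyl link joining the ring to the core. Nothing measured here explains the loss of potency.

The compounds shown leave open how much of the step belongs to the extra ring nitrogen and how much to the methyl link. A 4-methylpiperazin-1-yl group attached directly to the same ring carbon would help separate the two.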